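Aryl groups on the ring nitrogen: compounds 1 to 4

The source may hold more compounds than are shown below. What is called first, only, known or untested is meant among the compounds shown, and "the series" means these compounds.

Measured so far in a functional assay on A549 cells (Homo sapiens) for inhibition, read by MTT assay, with a stated time of 72 h; a lower number here means a stronger inhibitor, a higher number a weaker inhibitor:
compound 1 `Cc1ccc(N2CCN(C(=S)N/N=C3\C(=O)Nc4ccc(Cl)cc43)CC2)c(C)c1` gives 3590 nM.
compound 2 `O=C1Nc2ccc(Cl)cc2/C1=N/NC(=S)N1CCN(c2ccc(Cl)c(Cl)c2)CC1` gives 7950 nM.
compound 3 `O=C1Nc2ccc(Cl)cc2/C1=N/NC(=S)N1CCN(c2ccccc2F)CC1` gives 10500 nM.

Compound 3 has the highest number of the three. Against compound 2 it sits within the scatter; against compound 1 the gap is a 2.9-fold higher number from compound 1 to compound 3 (0.47 log units; beyond the scatter), and compound 2 differs from compound 1 by a 2.2-fold higher number from compound 1 to compound 2 (0.35 log units; beyond the scatter). The step of a 1.3-fold higher number from compound 2 to compound 3 (0.12 log units; within the scatter) shows that two rather different aryl groups on the ring nitrogen can give much the same number.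

Compound 4 `O=C1Nc2ccc(Cl)cc2/C1=N/NC(=S)N1CCN(c2ccc([N+](=O)[O-])cc2)CC1` changes the same position: 4-nitrophenyl in place of 2-fluorophenyl on an amine nitrogen in a ring. Among the compounds with values here, there is no measured analogue with a 4-nitrophenyl group, so the three aryl swaps are the only guide. Two of them are modest and one is within the scatter, all among the same shared core, so a step of at most modest size in this assay is expected, with no clear direction.

Compound 4 is estimated at 9000 nM, range 4000 nM to 20000 nM, that is an expected step of a 1.2-fold lower number from compound 3 to compound 4 (0.07 log units; within the scatter).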

Compound 4, half-maximal inhibitory concentration: 11800 nM
Compound 4: middle estimate off by 1.3-fold (0.12 log units), on the low side; measured number inside the range.
By their numbers in this assay, from the lowest: compound 1; then compounds 2, 3 and 4 (each within the scatter of the next).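

In this assay the 4-nitrophenyl group joins the cluster: a 1.1-fold higher number from compound 3 to compound 4 (0.05 log units; within the scatter) and a 1.5-fold higher number from compound 2 to compound 4 (0.17 log units; within the scatter) both leave compounds 2, 3 and 4 unresolved, even though 4-nitrophenyl brings 2 hydrogen-bond acceptors and 2-fluorophenyl brings 0. Compound 1, with its 2,4-dimethylphenyl group, is the only one that stands apart, and a 3.3-fold higher number from compound 1 to compound 4 (0.52 log units; beyond the scatter) makes it the strongest inhibitor of the four, though only modestly. Nothing available accounts for why compound 1 separates from the others.

Still open, on these data alone, is whether any other aryl group matches compound 1 or improves on it. Also open, as far as these compounds go, is how a benzyl group or a short alkyl chain on the ring nitrogen, or a phenyl carrying a carboxylic acid or an amine, would behave.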